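The compounds below may be only part of what the source reports. "The series", "measured", "known", "first", "only" and "open" are said of these compounds alone.

Measured compounds in a functional assay on CEM-DNR-bulk cells (Homo sapiens), read by MTT assay, with a stated time of 72 h; on this read-out higher numbers stand for weaker inhibition and lower numbers for stronger inhibition:
compound 1 `CNc1ncnc2c1c(I)cn2[C@@H]1O[C@H](CO)[C@@H](O)[C@H]1O` gives > 20000 nM, a limit.
compound 2 `CNc1ncnc2c1c(-c1ccccc1)cn2[C@@H]1O[C@H](CO)[C@@H](O)[C@H]1O` gives > 20000 nM, a limit.
compound 3 `CNc1ncnc2c1c(-c1ccoc1)cn2[C@@H]1O[C@H](CO)[C@@H](O)[C@H]1O` gives > 20000 nM, a limit.

Compound 3 stands nowhere on a scale of numbers: its value is a limit of this assay, and it shares that position with the two other measured compounds, since all three sit at the limit of > 20000 nM in this assay, at which 3 of the 3 values shown sit. Compound 3 can therefore be set neither above nor below compound 1 or compound 2.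

Compound 4 `CNc1ncnc2c1c(-c1ccco1)cn2[C@@H]1O[C@H](CO)[C@@H](O)[C@H]1O` differs from compound 3 by furan-2-yl in place of furan-3-yl on an aromatic carbon. Of the measured steps, a step that the two limits leave unreadable from compound 1 to compound 2, a step that the two limits leave unreadable from compound 1 to compound 3 and a step that the two limits leave unreadable from compound 2 to compound 3 all remain without a readable size because both ends of each sit at the limit of > 20000 nM in this assay, at which 3 of the 3 values shown sit. The one closest in kind to the present change, a step that the two limits leave unreadable from compound 2 to compound 3, exchanges one aromatic ring for another and still yields nothing readable. For the measured compounds named here, no measured step thus bears readably on the step to compound 4, and no size in either direction can be drawn from them; the expectation is that compound 4 too remains at the limit, so the step from compound 3 is expected to be a step that the limit leaves unreadable from compound 3 to compound 4. Compound 4 is accordingly estimated at 30000 nM in this assay, within 10000 nM to 100000 nM.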

Compound 4, half-maximal inhibitory concentration: > 20000 nM
Compound 4: no number, only a limit; the forecaster's own chance of this, stated with the estimate: 85%; the middle value does not contradict the limit.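

In this assay compound 4 gives > 20000 nM, a limit. No step to it from compound 1, compound 2 or compound 3 can be read: the limit of > 20000 nM in this assay, at which 4 of the 4 values shown sit.

The compounds shown leave open how iodo, phenyl, furan-3-yl and furan-2-yl rank against one another in this assay.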